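The compounds below may be only part of what the source reports. "The series", "measured", "known", "first", "only" and "open" are said of these compounds alone.

Measured in an assay on RBL-1 cells with Polyunsaturated fatty acid 5-lipoxygenase (Rattus norvegicus) as the target; a higher number here means a weaker inhibitor, a lower number a stronger inhibitor:
compound 1 `Cc1ccc2ccccc2c1O` gives 130 nM;
compound 2 `COc1ccc(Cc2ccc3ccccc3c2O)cc1` gives 75 nM;
compound 3 `COc1ccc2c(O)c(Cc3ccccc3)ccc2c1` gives 1900 nM.

Compound 2 holds the lowest of the three numbers. Compound 1 sits within the scatter of it, so no order can be drawn between those two; compound 3 lies well beyond the scatter, with the far higher number. Compound 4 `Oc1c(Cc2ccc(OCc3ccccc3)cc2)ccc2ccccc12` has not been measured. It differs from compound 2 by phenyl in place of hydrogen on a saturated chain carbon bound to an oxygen on an aromatic ring, that is methoxy to benzyloxy. Among the compounds with values here, no measured pair shows this change, so its direction is open. The step from compound 2 to compound 4 in this assay is expected to stay within the scatter, with no clear direction: a 1.1-fold lower number from compound 2 to compound 4 (0.03 log units; within the scatter). Compound 4 is therefore estimated at 70 nM, within 20 nM to 250 nM.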

Compound 4, half-maximal inhibitory concentration: 72 nM
Beside the measured number, compound 4's estimate is 1.0-fold (0.01 log units) below it, and the stated range covers the measured number.
By their numbers in this assay, from the lowest: compounds 4, 2 and 1 (each within the scatter of the next); then compound 3.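

In this assay, a 1.0-fold lower number from compound 2 to compound 4 (0.02 log units; within the scatter) shows that this site, a saturated chain carbon bound to an oxygen on an aromatic ring, accepts a whole added phenyl with no readable shift. Methoxy to benzyloxy is the only single-place step shown in the series, and it is flat. Nothing available accounts for this flat step.

Going by these compounds, whether an amine or a carboxylic acid on the added phenyl would also leave the number flat remains open. So does the outcome for a longer chain in place of benzyl.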